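A few compounds are considered here, and "the series" means these few. Any claim that something is new, unique, unknown or untested is made for them only; others in the source may bear on it.

Compound 1, `O=C(CSc1nc(Nc2ccccc2)c2ccccc2n1)Nc1ccccc1F`: a limit of > 50000 nM.
Compound 2, `O=C(CSc1nc(Nc2ccccc2)c2ccccc2n1)Nc1ccccc1Br`: 14100 nM.

Among the measured compounds shown here, in a functional assay on MDA-MB-231 cells (Homo sapiens) for inhibition, read by MTT assay, with a stated time of 72 h (on this read-out lower numbers stand for stronger inhibition and higher numbers for weaker inhibition), compound 2 gives 14100 nM, the only true number among the two values shown. The value of compound 1 is a limit (the limit of > 50000 nM in this assay, at which 1 of the 2 values shown sits). Compound 3, `O=C(CSc1nc(Nc2ccccc2)c2ccccc2n1)Nc1ccc(Cl)cc1`, differs from compound 2 by 4-chlorophenyl in place of 2-bromophenyl on an amide-type nitrogen. For the measured compounds named here, the single measured step, an at least 3.5-fold lower number from compound 1 to compound 2 (0.54 log units; beyond the scatter), swaps one halogen for another in the same ring and so bears only loosely on this change. The step from compound 2 to compound 3 is therefore expected to be small, a 1.1-fold higher number from compound 2 to compound 3 (0.03 log units; within the scatter). Compound 3 is estimated at 15000 nM, in a range from 5000 nM to 45000 nM.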

Compound 3, half-maximal inhibitory concentration: 17200 nM
For compound 3 the middle estimate is 1.1-fold (0.06 log units) below the measured one; measured number inside the range.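

Changing both the halogen and its place, from 2-bromophenyl to 4-chlorophenyl on the amide-type nitrogen, leaves the two compounds indistinguishable (a 1.2-fold higher number from compound 2 to compound 3 (0.09 log units; within the scatter)). The 4-chlorophenyl group also keeps the gain seen for 2-bromophenyl over 2-fluorophenyl (an at least 2.9-fold lower number from compound 1 to compound 3 (0.46 log units; beyond the scatter)). That step is open-ended, as compound 1 is known only as a limit: the limit of > 50000 nM in this assay, at which 1 of the 3 values shown sits.

The compounds shown leave open whether halogen identity and ring place matter separately here, since both change at once. They also leave open how a methoxy group, an amine or a carboxylic acid on this ring would read.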